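The compounds below may be only part of what the source reports. "The series", "measured", "known", "first", "only" and "open" are said of these compounds alone.

Compound 1 `CCn1cc(C(=O)O)c(=O)c2cc(F)c(N3CCN(C(=N)NS(=O)(=O)c4cccc(Cl)c4)CC3)cc21` gives 32 nM
Compound 2 `N=C(NS(=O)(=O)c1ccc(Cl)cc1)N1CCN(c2cc3c(cc2F)c(=O)c(C(=O)O)cn3C2CC2)CC1` gives 32 nM

In a functional assay on HeLa cells (Homo sapiens) for antiproliferative activity, read by MTT assay, with a stated time of 72 h (on this read-out higher numbers stand for weaker inhibition and lower numbers for stronger inhibition), compound 2 gives 32 nM and stands level with compound 1 within the scatter. Compound 3 `CCn1cc(C(=O)O)c(=O)c2cc(F)c(N3CCN(C(=N)NS(=O)(=O)c4ccc(Cl)cc4)CC3)cc21` is still to be measured and carries ethyl in place of cyclopropyl on an aromatic nitrogen relative to compound 2. Within the data shown here, no measured pair shows this change alone, so the size of the step in this assay can only be judged from the level of the two values at hand. The expectation is no step beyond the scatter and no firm direction. The expected step is a 1.1-fold higher number from compound 2 to compound 3 (0.04 log units; within the scatter) and it remains an estimate. Among the measured compounds shown here, only two values support it, so the range stays wide. For compound 3 the estimated value is 35 nM with an expected range from 12 nM to 100 nM as the likely span.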

Compound 3, half-maximal inhibitory concentration: 32 nM
Estimate against measurement, compound 3: 1.1-fold (0.04 log units) above; the measured number falls inside the stated range.
By their numbers in this assay, from the lowest: compounds 1, 2 and 3 (each within the scatter of the next).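

In this assay, among these compounds, ethyl in place of cyclopropyl on the aromatic nitrogen gives no change at the digits printed from compound 2 to compound 3 (within the scatter) as the first reading of this position with nothing else altered, so removal of the three-membered ring leaves the read-out level in this pair. Compound 3 also splits the two-place gap between compound 1 and compound 2 into single changes, and 4-chlorophenyl in place of 3-chlorophenyl on the sulfonyl sulfur gives no change at the digits printed from compound 1 to compound 3 (within the scatter) as the second of them. Nothing measured on these compounds speaks to why either change leaves the read-out level.

As far as these compounds go, whether the aromatic nitrogen would stay level with a longer chain such as n-butyl, or with benzyl, remains open. The same holds on the sulfonyl side for a methoxy group or an amine in place of the chlorine.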